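Trimethoxyphenyl series: hydroxy added on the pendant methoxyphenyl

The compounds below may be only part of what the source reports. "The series", "measured", "known", "first", "only" and "open" are said of these compounds alone.

Measured compounds:
compound 1 `COc1cc(-n2cnc3ccc(-c4ccc(C(F)(F)F)cc4)cc32)cc(OC)c1OC`, 890 nM
compound 2 `COc1cccc(-c2ccc3ncn(-c4cc(OC)c(OC)c(OC)c4)c3c2)c1`, 3310 nM
compound 3 `COc1ccc(-c2ccc3ncn(-c4cc(OC)c(OC)c(OC)c4)c3c2)cc1`, 82 nM

In a functional assay on SGC-7901 cells (Homo sapiens) for antiproliferative activity, read by MTT assay, with a stated time of 72 h (a higher number here means a weaker inhibitor, a lower number a stronger inhibitor), compound 3 gives the lowest number of the three and is the most potent here, since the steps to both others lie beyond the scatter: an 11-fold lower number from compound 1 to compound 3 (1.04 log units; beyond the scatter) and a 40-fold lower number from compound 2 to compound 3 (1.61 log units; beyond the scatter). Compound 4 `COc1ccc(-c2ccc3ncn(-c4cc(OC)c(OC)c(OC)c4)c3c2)cc1O` differs from compound 3 by hydroxy in place of hydrogen on an aromatic carbon. Among the measured compounds shown here, no measured step adds a hydroxy, so the change is uncharted; a 40-fold lower number from compound 2 to compound 3 (1.61 log units; beyond the scatter) shows only that the placing of groups on that ring matters strongly. Compound 4 is therefore expected to stay close to compound 3, within the scatter or a modest shift either way, as a 1.2-fold higher number from compound 3 to compound 4 (0.09 log units; within the scatter). The estimate for compound 4 in this assay is 100 nM, from 30 nM to 400 nM.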

Compound 4, half-maximal inhibitory concentration: 44 nM
The estimate for compound 4 lay 2.3-fold (0.36 log units) above the measured number, within the range that was stated.
By their numbers in this assay, from the lowest: compounds 4 and 3 (each within the scatter of the next); then compound 1; then compound 2.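

In this assay, hydroxy on the aromatic carbon ortho to a methoxy group is tolerated, with a 1.9-fold lower number from compound 3 to compound 4 (0.27 log units; within the scatter). The 3-hydroxy-4-methoxyphenyl group thus stays well ahead of the other two pendant groups, with a 75-fold lower number from compound 2 to compound 4 (1.88 log units; beyond the scatter) and a 20-fold lower number from compound 1 to compound 4 (1.31 log units; beyond the scatter). No supporting data bear on the reason for this tolerance. As far as these compounds go, whether an amine or a fluorine at the same place would keep this level remains open. Also open, from the compounds shown here alone, is whether hydroxy would have any comparable outcome on the 3-methoxyphenyl group of compound 2.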